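The source may report more compounds than this note shows. Statements on the series, on what has been measured and on what is new or still open speak of the compounds shown alone.

Measured so far in a functional assay on MT2 cells (Homo sapiens) for antiproliferative activity, read by MTT assay, with a stated time of 72 h (a lower number here means a stronger inhibitor of growth, a higher number a weaker inhibitor of growth), are two compounds
compound 1 `O=C(COc1ccc2oc(-c3ccccc3)cc(=O)c2c1)Nc1ccc(F)cc1` with 470 nM
compound 2 `COc1ccc(NC(=O)COc2ccc3oc(-c4ccccc4)cc(=O)c3c2)cc1` with 3010 nM

Compound 2, at 3010 nM in this assay, holds the higher of the two numbers and is so far the weaker inhibitor of growth. Compound 3 `O=C(COc1ccc2oc(-c3ccccc3)cc(=O)c2c1)Nc1ccc(-c2ccccc2)cc1` carries phenyl in place of methoxy on an aromatic carbon, para to a large group (phenyl in place of methoxy on an aromatic carbon). Among the compounds with values here, only one measured step bears on this change. It is a 6.4-fold higher number from compound 1 to compound 2 (0.81 log units; beyond the scatter), made on the same aromatic carbon with methoxy in place of fluoro. Within the data shown here, no measured compound carries phenyl there, so this single step gives a direction only weakly. A small further rise in this assay is expected, smaller than that step. The expected step is a 2.2-fold higher number from compound 2 to compound 3 (0.33 log units; beyond the scatter) as an estimate. Compound 3 is estimated at 6500 nM with an expected range from 1200 nM to 30000 nM as its likely span.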

Compound 3, concentration for 50% growth inhibition: > 10000 nM
Compound 3 ended at the assay's limit; the forecaster's own chance of this, stated with the estimate: 10%; middle value at least 1.5-fold (0.18 log units) away from the limit.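

Phenyl in place of methoxy gives an at least 3.3-fold higher number from compound 2 to compound 3 (0.52 log units; beyond the scatter) in this assay, and phenyl in place of fluoro gives an at least 21-fold higher number from compound 1 to compound 3 (1.32 log units; beyond the scatter), so a third group on this aromatic carbon moves the number the same way as the earlier change from fluoro to methoxy. The value of compound 3, > 10000 nM, is a limit of the assay and not a number: the limit of > 10000 nM in this assay, at which 1 of the 3 values shown sits. At this position the number rises in the order fluoro, methoxy, phenyl, and none of the three compounds goes against that order, though three groups are too few to make it a rule.

The compounds shown leave open where an amine, a carboxylic acid or a short alkyl chain on this carbon would fall in that order. They also leave open whether any group there would give a lower number than fluoro does.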